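This account rests on a few compounds, and the source may have more. Where it says the series, first, only, none or still open, it means among the compounds named here.

Measured so far in a functional assay on T47D cells (Homo sapiens) for antiproliferative activity, read by MTT assay, with a stated time of 72 h (a higher number here means a weaker inhibitor, a lower number a stronger inhibitor), and one compound still to come:
compound 1 `O=C(Nc1ccc(Cl)c(-c2nnc3c(Cl)cccn23)c1)c1ccc(F)cc1Cl` gives > 100000 nM, which is a limit of the assay and not a number.
compound 2 `CS(=O)(=O)c1ccc(C(=O)Nc2ccc(Cl)c(-c3nnc4c(Cl)cccn34)c2)cc1` gives > 100000 nM, again a limit rather than a number.
compound 3 `CS(=O)(=O)c1ccc(C(=O)Nc2ccc(Cl)c(-c3nnc4c(Cl)cccn34)c2)c(Cl)c1` has not yet been measured.

Compound 2 thus stands only at the limit of > 100000 nM in this assay, at which 2 of the 2 values shown sit, with no number of its own. Among the compounds with values here, the single measured step, a step that the two limits leave unreadable from compound 1 to compound 2, cannot be read because both ends are limits. Compound 3 differs from compound 2 by chloro in place of hydrogen on an aromatic carbon. No measured step bears on this change, and the one step shown has no readable size, so the data give no direction at all; the expectation is simply that compound 3 remains where compound 2 stands, beyond any step outside the scatter. Compound 3 is therefore estimated to give 150000 nM, in a range from 40000 nM to 1000000 nM, most probably reported once more as a limit. The expected step is a step that the limit leaves unreadable from compound 2 to compound 3.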

Compound 3, half-maximal inhibitory concentration: > 100000 nM
Compound 3 was reported as a limit; the forecaster's own chance of this, stated with the estimate: 85%; the middle value is on the limit's open side.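

No new step can be read from compound 3 to compound 2 or compound 1, as all three compounds stand at a limit of the assay and not at a number: the limit of > 100000 nM in this assay, at which 3 of the 3 values shown sit.

The compounds shown leave open whether chloro in place of hydrogen, or any other change among them, shifts the read-out at all.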